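The source may report more compounds than this note shows. Statements on the series, on what has been measured and on what is new or still open speak of the compounds shown alone.

Of the compounds shown here, two have been measured in an assay on membranes from CHO cells for displacement of a labelled ligand from adenosine receptor A1 (Homo sapiens), read by scintillation counting, with a stated time of 60 min, tested at 1 uM; a higher number here means more inhibition at the concentration tested (going by the name of the read-out), a lower number less inhibition. Compound 1, `CCN(CC)C(=O)C1=C(C)NC(=O)NC1c1cccs1`, gives 13%. Compound 2, `CCC(CC)OC(=O)C1=C(C)NC(=O)NC1c1ccco1`, gives 2%. On these two numbers compound 2 stands lowest; its nearest neighbour is compound 1, whose reading is higher by a margin that lies beyond the scatter of the measurement. Compound 1 and compound 2 differ in more than one place, so nothing further is drawn from that pair.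

The next compound, compound 3, `CCC(CC)OC(=O)C1=C(C)NC(=O)NC1c1cccs1`, is still to be measured in this assay. It is reached from compound 2 by a single change: thiophen-2-yl in place of furan-2-yl on a saturated ring carbon. The same thiophen-2-yl group is present in compound 1, but compound 1 also carries a different group on the ring atom that bears the group of 8 heavy atoms, so its value is only a loose guide. The step is expected to be small, upward if anything, and may well fall within the scatter: the estimated step is a number 6 percentage points higher from compound 2 to compound 3 (within the scatter). For compound 3 the expected inhibition in this assay is 8%, within a range from 0% to 20%.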

Compound 3, a percentage reported as inhibition, at one concentration (the size of the read-out at that concentration, not a potency): 13%
The estimate for compound 3 lay 5 percentage points below the measured number; measured number inside the range.
By their numbers in this assay, from the lowest: compound 2; then compounds 1 and 3 (each within the scatter of the next).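

On the saturated ring carbon, with (pentan-3-yl)oxy held on the carbonyl carbon, thiophen-2-yl in place of furan-2-yl gives a number 11 percentage points higher from compound 2 to compound 3 (beyond the scatter) in this assay and so isolates this position, which the pair of compound 1 and compound 2 could not do. With thiophen-2-yl held, (pentan-3-yl)oxy in place of diethylamino on the carbonyl carbon gives no change at the digits printed from compound 1 to compound 3 (within the scatter) and so does not separate these two groups in this assay, although this single comparison at one concentration says nothing about potency. Nothing available accounts for the gain from the sulfur-containing ring over the oxygen-containing ring.

The compounds shown do not tell whether the step on the saturated ring carbon would carry over to a diethylamino series, or whether a phenyl ring or a thiophen-3-yl group at the same place would extend it. They also leave open whether a shorter ethoxy group or a free carboxylic acid on the carbonyl carbon would move the reading away from that of compound 3 at 13% in this assay.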